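Swapping a fluorophenyl for a methylpyrazole on a shared core

The source may report more compounds than this note shows. Statements on the series, on what has been measured and on what is new or still open speak of the compounds shown alone.

Of the compounds shown here, three built on one shared core have been tested in an assay on CHO cells for antagonist activity at Orexin receptor type 2 (Homo sapiens), read by FLIPR, with a stated time of 5 min; on this read-out lower numbers stand for stronger inhibition and higher numbers for weaker inhibition. Compound 1 `COc1ccc(CNC(=O)c2cc(-c3cncc(C)c3)ncc2-c2cnccn2)nc1OC` gives 109 nM, compound 2 `COc1ccc(CNC(=O)c2cc(-c3cncc(C)c3)ncc2N2CCC2)nc1OC` gives 83 nM, and compound 3 `COc1ccc(CNC(=O)c2cc(-c3cncc(C)c3)ncc2-c2ccccc2F)nc1OC` gives 25 nM. Compound 3 thus holds the lowest number of the three, with a 4.4-fold lower number from compound 1 to compound 3 (0.64 log units; beyond the scatter) and a 3.3-fold lower number from compound 2 to compound 3 (0.52 log units; beyond the scatter), both beyond the usual scatter. Compound 4 `COc1ccc(CNC(=O)c2cc(-c3cncc(C)c3)ncc2-c2cnn(C)c2)nc1OC` differs from compound 3 in one place: 1-methyl-1H-pyrazol-4-yl in place of 2-fluorophenyl on an aromatic carbon. The two steps that lead into compound 3 both bear on this change: each replaced another group at this position, pyrazin-2-yl in compound 1 and azetidin-1-yl in compound 2, with 2-fluorophenyl, and each gave a modest drop in the number. The group entering in compound 4 is a five-membered aromatic ring with hetero atoms, closer in kind to the pyrazin-2-yl of compound 1 than to 2-fluorophenyl, so the number is expected to climb back by a modest amount, a 3.2-fold higher number from compound 3 to compound 4 (0.51 log units; beyond the scatter). Compound 4 is therefore estimated at 80 nM in this assay, with a likely range from 30 nM to 250 nM.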

Compound 4, half-maximal inhibitory concentration: 167 nM
Compound 4: the middle estimate sits 2.1-fold (0.32 log units) below what was measured; the measured number falls inside the stated range.
By their numbers in this assay, from the lowest: compound 3; then compounds 2, 1 and 4 (each within the scatter of the next).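

Putting 1-methyl-1H-pyrazol-4-yl in place of 2-fluorophenyl gives a 6.7-fold higher number from compound 3 to compound 4 (0.82 log units; beyond the scatter) and so shows that the low number of compound 3 does not carry over to this five-membered aromatic ring with 2 hetero atoms. Compound 4 also cannot be told apart from the two other compounds, with a 2.0-fold higher number from compound 2 to compound 4 (0.30 log units; within the scatter) and a 1.5-fold higher number from compound 1 to compound 4 (0.19 log units; within the scatter) as the steps. Of the four groups tested at this position, only 2-fluorophenyl, the one ring of carbon only, stands apart from the rest.

From the compounds shown here alone, whether a plain phenyl without its fluorine, or a morpholine, would keep the low number of compound 3 remains open. What sets 2-fluorophenyl apart also remains open, as no measurement here offers an explanation.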